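Sulfonamide series: branching the benzylic carbon of compound 2

This account rests on a few compounds, and the source may have more. Where it says the series, first, only, none or still open, it means among the compounds named here.

Two compounds of the shared core have numbers. In a functional assay on HEK293 cells for antagonist activity at Voltage-dependent T-type calcium channel subunit alpha-1H (Homo sapiens), read by patch clamp, tested at 1 uM (a lower number here means less inhibition, a higher number more inhibition at the concentration tested (going by the name of the read-out)), compound 1 `CC(=O)N(CCCN(C)C(=O)c1ccc(Oc2ccccc2)cc1)Cc1cccc(Cl)c1` gives 5%. Among the measured compounds shown here, compound 2 `CC(=O)N(CCCN(C)S(=O)(=O)c1ccc(Oc2ccccc2)cc1)Cc1cccc(Cl)c1`, the sulfonamide counterpart, gives 30% in this assay and stands highest of the two; the only other number, that of compound 1, lies lower by a gap beyond the usual scatter.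

Compound 3 `CC(=O)N(CCCN(C)S(=O)(=O)c1ccc(Oc2ccccc2)cc1)C(CC(=O)OC(C)C)c1cccc(Cl)c1` keeps the sulfonamide of compound 2 and differs from it in one place: (isopropoxycarbonyl)methyl in place of hydrogen on a saturated chain carbon bound to an amide-type nitrogen and an aromatic carbon. For the measured compounds named here, no measured pair shows a change of this kind, so the direction of the step is open. Given that compound 2 already gives 30%, a modest upward step is expected, with the move from compound 2 to compound 3 estimated at a number 10 percentage points higher from compound 2 to compound 3 (within the scatter), which may still lie within the scatter.

For compound 3 the expected inhibition in this assay is 40%, estimated to fall between 15% and 65%.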

Compound 3, a percentage reported as inhibition, at one concentration (the size of the read-out at that concentration, not a potency): 17%
For compound 3 the middle estimate is 23 percentage points above the measured one; the measured number falls inside the stated range.
By their numbers in this assay, from the lowest: compound 1; then compound 3; then compound 2.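

In this assay, the saturated chain carbon bound to an amide-type nitrogen and an aromatic carbon gives its first readable step: (isopropoxycarbonyl)methyl in place of hydrogen there yields a number 13 percentage points lower from compound 2 to compound 3 (beyond the scatter). The position therefore responds to substitution, and this change lowers the number rather than raising it, although compound 3 still gives 17%. Nothing available here speaks to the cause of this step.

This single pair cannot show whether the step follows from branching at that carbon as such or from the isopropyl ester carried on the new chain. A plain methyl on that saturated chain carbon, or a carboxylic acid in place of the ester, would bear directly on that question.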